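Swapping iodo for azido on compound 3

This account rests on a few compounds, and the source may have more. Where it says the series, first, only, none or still open, it means among the compounds named here.

Compound 3 `O=c1[nH]c(=O)n([C@@H]2O[C@H](CO)[C@@H](O)[C@H]2O)c(I)c1F` carries both an iodo and a fluoro group on the shared core. In a functional assay on OCI-AML2 cells (Homo sapiens) for antiproliferative activity, read by WST assay, with a stated time of 3 days (a lower number here means a stronger inhibitor, a higher number a weaker inhibitor), compound 3 gives only a limit, > 50000 nM. Compound 1 `O=c1cc(I)n([C@@H]2O[C@H](CO)[C@@H](O)[C@H]2O)c(=O)[nH]1`, without the fluoro group, also gives only a limit, > 50000 nM. Compound 2 `[N-]=[N+]=Nc1cc(=O)[nH]c(=O)n1[C@@H]1O[C@H](CO)[C@@H](O)[C@H]1O`, with azido in place of iodo, again gives only a limit, > 50000 nM. All three therefore rest at the limit of > 50000 nM in this assay, at which 3 of the 3 values shown sit, and compound 3 cannot be ranked against the other two.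

Compound 4 `[N-]=[N+]=Nc1c(F)c(=O)[nH]c(=O)n1[C@@H]1O[C@H](CO)[C@@H](O)[C@H]1O` follows from compound 3 by one change, (azido in place of iodo on an aromatic carbon). The same exchange has been tried once without the fluoro group, as a step that the two limits leave unreadable from compound 1 to compound 2. Adding the fluoro group is the other measured change, a step that the two limits leave unreadable from compound 1 to compound 3. Neither measured step has a readable size, so neither supplies a size to carry over, and neither shows a gain from azido or from fluoro alone. Any number that compound 4 gives could only lie on the stronger side of the limit, and a further limit is about as likely as a number.

The expected change is small and very uncertain, estimated as an at least 1.6-fold lower number from compound 3 to compound 4 (0.22 log units; that floor lies within the scatter). The estimate for compound 4 is 30000 nM, with an expected range from 3000 nM to 60000 nM.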

Compound 4, half-maximal inhibitory concentration: 700 nM
The estimate for compound 4 lay 43-fold (1.63 log units) above the measured number; the measured number lies below the stated range.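

In this assay, azido in place of iodo, with the carbon ortho to a fluoro group, now has a size: an at least 71-fold lower number from compound 3 to compound 4 (1.85 log units; beyond the scatter). Fluoro in place of hydrogen, with azido already on the neighbouring ring position of the shared core, has one too: an at least 71-fold lower number from compound 2 to compound 4 (1.85 log units; beyond the scatter). The earlier steps among compound 1, compound 2 and compound 3 cannot be read, and only the pairing of azido with fluoro in compound 4 gives a number, while each group without the other stays at the limit: the limit of > 50000 nM in this assay, at which 3 of the 4 values shown sit.

Both new steps are floors and their full sizes stay open, and the compounds shown do not tell whether the gain belongs to azido and fluoro in particular. An amine or a nitrile in the place of azido, or a chloro group or a methyl group in the place of fluoro, would test how narrow this pairing is on the shared core.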